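A few compounds are considered here, and "the series" means these few. Any claim that something is new, unique, unknown or untested is made for them only; others in the source may bear on it.

Compound 1 `O=C(CN(c1nc(Cl)nc2[nH]cnc12)C1CC1)NCC(=O)OCc1ccccc1` gives 18.7% in a functional assay on the whole organism (Tail, strain ICR) with Mus musculus as the target, in the tail flick test, with a stated time of 30 min, at a dose of 25 umol/kg by the oral route; a lower number here means a weaker effect, a higher number a stronger effect of the compound at the dose given. For the measured compounds named here, that is the lower of the two numbers measured so far. Compound 2 `O=C(CN(c1ncnc2c1ncn2C1CCCCO1)C1CC1)N[C@@H](CCC(=O)OCc1ccccc1)C(=O)OCc1ccccc1` gives 32.6% in this assay, a reading that lies above compound 1 by more than the usual scatter. Compound 3 `O=C(CN(c1nc(Cl)nc2[nH]cnc12)C1CC1)N[C@@H](CCC(=O)OCc1ccccc1)C(=O)OCc1ccccc1` is not yet measured. It differs from compound 1 as follows: 2-(benzyloxycarbonyl)ethyl in place of hydrogen on a saturated chain carbon bound to an amide-type nitrogen and a carbonyl carbon. Compound 3 therefore carries the 2-(benzyloxycarbonyl)ethyl group found in compound 2 on the core of compound 1. Going by the values given here, no measured pair isolates this change on its own. A moderate rise is expected, with the step of a number 9.3 percentage points higher from compound 1 to compound 3 (within the scatter) not certain to exceed the scatter, because compound 2 reads 32.6% with this group in place. Compound 3 is expected to give 28% in this assay, within a range from 12% to 45%.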

Compound 3, a percentage reported as activity, at one dose (the size of the read-out at that dose, not a potency): 52.8%
The estimate for compound 3 lay 24.8 percentage points below the measured number; measured number outside the range, above it.
By their numbers in this assay, from the lowest: compound 1; then compound 2; then compound 3.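

In this assay, 2-(benzyloxycarbonyl)ethyl in place of hydrogen on a saturated chain carbon bound to an amide-type nitrogen and a carbonyl carbon gives a number 34.1 percentage points higher from compound 1 to compound 3 (beyond the scatter). For the compounds shown here, this is the first comparison that differs in one place, and it shows that the reading at this dose responds strongly to substitution at this position on the core of compound 1. Nothing available explains the size of this step.

On these data alone, whether the step belongs to the benzyl ester, the chain or the aromatic ring remains open, and a carboxylic acid in place of the benzyl ester, a shorter chain or a longer chain at this position would help separate them. A reading at one dose also leaves the potency of compound 3 undefined.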